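The source may report more compounds than this note shows. Statements on the series, on what has been measured and on what is new or still open speak of the compounds shown alone.

Measured in a functional assay on K562 cells (Homo sapiens), read by MTT assay, with a stated time of 72 h; on this read-out higher numbers stand for weaker inhibition and lower numbers for stronger inhibition:
Compound 1 `Nc1nc(N)c2c(-c3ccsc3)cn([C@@H]3O[C@H](CO)[C@@H](O)[C@H]3O)c2n1`: > 20000 nM
Compound 2 `COc1nc(N)nc2c1c(-c1ccoc1)cn2[C@@H]1O[C@H](CO)[C@@H](O)[C@H]1O`: > 20000 nM

Compound 2 gives > 20000 nM, which is a limit of the assay and not a number. The same holds for the other measured compound, so the picture so far is the limit of > 20000 nM in this assay, at which 2 of the 2 values shown sit. Among the measured compounds shown here, no exact potency is therefore known for either compound, and no measured step is available as a guide.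

Compound 3 `COc1nc(N)nc2c1c(-c1ccsc1)cn2[C@@H]1O[C@H](CO)[C@@H](O)[C@H]1O` keeps the core of compound 2 but has thiophen-3-yl in place of furan-3-yl on an aromatic carbon. Compound 1 also carries thiophen-3-yl, and compound 1 gives > 20000 nM, again a limit.

In this assay, no change beyond the usual scatter is expected, and the expected step is a number no higher from compound 2 to compound 3 (the limit leaves the size open). For compound 3 the estimated value is 20000 nM, with an expected range of 7000 nM to 40000 nM.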

Compound 3, half-maximal inhibitory concentration: > 20000 nM
Compound 3: only a limit was reported (the forecaster's own chance of this, stated with the estimate: 80%); the middle value sits exactly at the limit.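

In this assay compound 3 gives > 20000 nM, a limit of the assay and not a number, so its steps from compound 1 and compound 2 cannot be read. The compounds shown leave open the exact potency of each and whether swapping furan-3-yl for thiophen-3-yl, or amino for methoxy, changes it: the limit of > 20000 nM in this assay, at which 3 of the 3 values shown sit.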